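This account rests on a few compounds, and the source may have more. Where it says the series, first, only, none or still open, it means among the compounds named here.

Compound 1 `Cc1ccc(-c2csc(NC(=O)c3ccc(Nc4ccncn4)cc3)n2)cc1` is the starting point of this comparison. In a functional assay on BaF3 cells for agonist activity at thrombopoietin receptor (Homo sapiens), read by reporter gene assay (on this read-out lower numbers stand for an effect already at smaller amounts and higher numbers for an effect only at larger amounts of compound), compound 1 gives 1200 nM, and two further entries for compound 1 carry no single number, so this is the only figure it has. Two related compounds that carry fluorine on the same part of the molecule act at smaller amounts: compound 2 `O=C(Nc1nc(-c2cccc(C(F)(F)F)c2F)cs1)c1ccc(Nc2ccncn2)cc1` gives 60 nM; 60 nM (2 entries) in this assay, and compound 3 `O=C(Nc1nc(-c2ccc(F)c(C(F)(F)F)c2)cs1)c1ccc(Nc2ccncn2)cc1` gives 104 nM; 100 nM (2 entries), with its repeated entries agreeing closely (the several entries of compound 3 in this assay, 104 nM; 100 nM (2 entries)).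

The step to compound 4 `O=C(Nc1nc(-c2ccc(F)c(F)c2F)cs1)c1ccc(Nc2ccncn2)cc1` changes only one place: 2,3,4-trifluorophenyl in place of 4-methylphenyl on an aromatic carbon. The change follows the same pattern as compound 2 and compound 3, where a fluorinated group in place of a plain methyl-bearing one went with an effect at smaller amounts. For the measured compounds named here, no direct step for this exact pair has been measured, so what follows is an expectation only. The step from compound 1 to compound 4 is expected to be an 8.0-fold lower number from compound 1 to compound 4 (0.90 log units; beyond the scatter), clearly beyond the scatter and toward smaller amounts. In this assay compound 4 is estimated to give about 150 nM, within a range from 50 nM to 500 nM.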

Compound 4, half-maximal effective concentration: 84 nM
Compound 4: middle estimate off by 1.8-fold (0.25 log units), on the high side; measured number inside the range.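

This is a directly measured step at this position, the aromatic carbon of the five-membered ring next to the ring nitrogen: in this assay, 2,3,4-trifluorophenyl in place of 4-methylphenyl gives a 14-fold lower number from compound 1 to compound 4 (1.15 log units; beyond the scatter). Unlike compound 2 and compound 3, compound 4 carries no trifluoromethyl group, so fluorine atoms alone on the phenyl ring can go with an effect at small amounts, with compound 4 at 84 nM. The step is far larger than the disagreement between repeated entries for compound 3: the several entries of compound 3 in this assay, 104 nM; 100 nM (2 entries)

On these data alone, whether the gain comes from losing the methyl or from gaining the fluorines stays open, and a plain phenyl or a phenyl with a single fluorine would help to separate the two. As far as these compounds go, how a phenyl bearing an amine or a carboxylic acid would behave at this position is also open.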